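The compounds below may be only part of what the source reports. "The series", "measured", "known", "first", "only" and "open" are said of these compounds alone.

Series notes, D(4) functional read-out

Four compounds sharing a piperazine-linked oxime motif are on hand. Compound 1 `O/N=C(\CCN1CCN(c2ccccn2)CC1)c1ccc(Cl)cc1` and compound 2 `CO/N=C(\CCN1CCN(c2ccccn2)CC1)c1ccc(Cl)cc1` share one core; compound 3 `O/N=C(\CCCN1CCN(c2ccccn2)CC1)c1ccc(F)cc1` and compound 4 `CO/N=C(\CCCN1CCN(c2ccccn2)CC1)c1ccc(F)cc1` share another. The difference between the two cores is not broken down here.

In a functional assay on HEK293 cells with D(4) dopamine receptor (Homo sapiens) as the target, read by FLIPR (on this read-out lower numbers stand for an effect already at smaller amounts and higher numbers for an effect only at larger amounts of compound), compound 1 gives 475 nM. In this assay compound 2 gives 37.6 nM. Among the measured compounds shown here, the only change between them is methyl in place of hydrogen on an oxygen, and it produced a 13-fold lower number from compound 1 to compound 2 (1.10 log units; beyond the scatter). In this assay compound 3 gives 9.5 nM, the lowest number of the three measured compounds, and its steps to compound 2 and to compound 1 both lie beyond the scatter.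

Compound 4 is not yet measured. It differs from compound 3 by methyl in place of hydrogen on an oxygen; the place of the change is the same as in the earlier pair, so this is the same change made on the second core. For the measured compounds named here, whether it carries over from one core to the other is the open question, since only one instance of it has been measured so far. On the strength of that one instance, a step of roughly comparable direction is expected in this assay, though compound 3 already starts from a low number and some shrinkage of the step would not be surprising: the expected step is a 6.3-fold lower number from compound 3 to compound 4 (0.80 log units; beyond the scatter), resting on a 13-fold lower number from compound 1 to compound 2 (1.10 log units; beyond the scatter) and on the starting number of compound 3, 9.5 nM. Compound 4 is therefore estimated at 1.5 nM in this assay, with an expected range from 0.4 nM to 6 nM.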

Compound 4, half-maximal effective concentration: 41.7 nM
Compound 4: middle estimate off by 28-fold (1.44 log units), on the low side; measured number above the stated range.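

In this assay, hydroxy to methoxy on the second core gives a 4.4-fold higher number from compound 3 to compound 4 (0.64 log units; beyond the scatter), so the step runs in the opposite direction to the one on the first core, and the two steps differ clearly: the same change on two cores in this assay, a 13-fold lower number (1.10 log units; beyond the scatter) from compound 1 to compound 2 and a 4.4-fold higher number (0.64 log units; beyond the scatter) from compound 3 to compound 4, 55-fold (1.74 log units) apart, beyond the scatter of two such steps

This shows that, across these two pairs, the effect of methyl in place of hydrogen on the oxygen does not carry over from one core to the other, and that a step measured on one core is a poor guide to the same change on the other. Among the compounds shown here, it does not show which part of the difference between the cores goes with the reversal, why the direction changes, or which direction would appear on any further core, since the comparison rests on only two pairs.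

Open, as far as these compounds go, is whether a core that differs from either of these in one place only would follow compound 1 and compound 2 or compound 3 and compound 4, which would tie the reversal to a single part of the core. Also open, from the compounds shown here alone, is whether an ethyl group or a longer chain on the same oxygen would follow the methyl on each core.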